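This account rests on a few compounds, and the source may have more. Where it says the series, first, only, none or still open, it means among the compounds named here.

Compound 1 `OC[C@H]1C[C@@H](Cn2cnc3c(-c4ccc(Cl)cc4)ncnc32)c2ccccc21` is measured in an ADME assay on L1210/0 cells (Mus musculus) for cytotoxicity, with a stated time of 48 h (a lower number here means a stronger inhibitor, a higher number a weaker inhibitor), next to two compounds of very different build, compound 2 `CC1=C(C)C(=O)C(c2cn([C@H]3C[C@H](O)[C@@H](CO)O3)c(=O)[nH]c2=O)=C(C)C1=O` and compound 3 `O=c1[nH]c(=O)n([C@H]2C[C@H](O)[C@@H](CO)O2)cc1[N+](=O)[O-]`. In this assay compound 1 gives 8440 nM as its reading, which puts it in the middle of the three numbers. On the weaker side, compound 2 reads 174000 nM and lies clearly beyond the usual scatter from compound 1. On the stronger side, compound 3 reads 130 nM and is also separated from compound 1 by more than the scatter.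

The compound still to be measured, compound 4 `CCOc1ncnc2c1ncn2C[C@@H]1C[C@H](CO)c2ccccc21`, keeps the core of compound 1 and alters one group: ethoxy in place of 4-chlorophenyl on an aromatic carbon. In plain terms, ethoxy takes the place of 4-chlorophenyl on an aromatic carbon. Among the measured compounds shown here, no two measured compounds here differ in just one place, so the data give no direct guide to the size of such a step. Taking compound 1 at 8440 nM as the starting point, a loss of strength seems more likely than a gain, since a whole aromatic ring departs, though this remains uncertain. In this assay the expected step is a 4.1-fold higher number from compound 1 to compound 4 (0.62 log units; beyond the scatter) and it points toward weaker inhibition. The estimated value for compound 4 is 35000 nM with an expected range from 10000 nM to 150000 nM.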

Compound 4, half-maximal inhibitory concentration: > 200000 nM
Compound 4: only a limit was reported; the forecaster's own chance of this, stated with the estimate: 25%; at least 5.7-fold (0.75 log units) between middle value and limit.
By their numbers in this assay, from the lowest: compound 3; then compound 1; then compound 2. At a limit, above all of these: compound 4.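

Among the compounds shown, this is the first single change to the core of compound 1, and it gives the earlier data something they lacked, a measured size for a step at this position: in this assay, ethoxy in place of 4-chlorophenyl on this aromatic carbon gives an at least 23-fold higher number from compound 1 to compound 4 (1.37 log units; beyond the scatter). The position is therefore not indifferent to what it carries, as compound 1 with its 4-chlorophenyl gives a countable reading, whereas compound 4 with ethoxy, which has no ring and fewer heavy atoms, does not. The reading of compound 4 is a limit of the assay and not a number, so the step has a lower bound but no known upper end: the limit of > 200000 nM in this assay, at which 1 of the 4 values shown sits.

The compounds shown cannot separate the loss of the aromatic ring from the arrival of the ethoxy oxygen, as both happen in a single step. A plain phenyl ring, a methoxy group or an amine on the same aromatic carbon would show which part of the change matters, and whether any smaller group keeps a countable reading.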